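The source may report more compounds than this note shows. Statements on the series, on what has been measured and on what is new or still open speak of the compounds shown alone.

Compound 1 `COc1ccc2nc(C)cc(OC3CCN(c4ccccc4)C3=O)c2c1` gives 4.99 in a physicochemical assay for lipophilicity, read by HPLC, in phosphate buffer, measured as chromatographic lipophilicity, at pH 7.4; a lower number here means a more polar compound, a higher number a more lipophilic compound.
Compound 2 `COc1ccc2nc(C)cc(OCC(=O)Nc3cccc(C)c3)c2c1` gives 4.83 in this assay.

Of the two numbers in this assay, compound 2 has the lower one, yet the nearest number, that of compound 1, lies only a little higher and within the scatter, so these two values set no order between them. Compound 3 `COc1ccc2nc(C)cc(OCC(=O)Nc3cc(C)nc(C)n3)c2c1` has not yet been measured in this assay. It differs from compound 2 in one place: 2,6-dimethylpyrimidin-4-yl in place of 3-methylphenyl on an amide-type nitrogen. Among the measured compounds shown here, no step between measured compounds is available here, so the expectation rests on the structural change and on the value of compound 2 alone. The estimated step of a number 1.13 log units lower from compound 2 to compound 3 (beyond the scatter) is expected to be a fall, clearly beyond the scatter, when 2,6-dimethylpyrimidin-4-yl stands in place of 3-methylphenyl on the amide-type nitrogen. For compound 3 the estimated value in this assay is 3.7, with a range from 3 to 4.4.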

Compound 3, distribution coefficient: 3.24
For compound 3 the middle estimate is 0.46 log units above the measured one, and the stated range covers the measured number.
By their numbers in this assay, from the lowest: compound 3; then compounds 2 and 1 (each within the scatter of the next).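

In this assay, the amide-type nitrogen proves to be a place where the attached ring counts for much: 2,6-dimethylpyrimidin-4-yl in place of 3-methylphenyl gives a number 1.59 log units lower from compound 2 to compound 3 (beyond the scatter). Among the compounds shown here, compounds 1 and 2 differ in more than one place and stand within the scatter of each other, so this is the first reading of a single change, and it lies well beyond the scatter. The entering group has two ring nitrogens, counted as hydrogen-bond acceptors, where the leaving group has none, but nothing shown gives a measured reason for the step.

The compounds shown leave open how much of the step a single ring nitrogen would carry, as a methylpyridinyl group on the same amide-type nitrogen would show. They also leave open whether the exchange would give a step of like size with a longer chain carrying the amide.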